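This account rests on a few compounds, and the source may have more. Where it says the series, first, only, none or still open, it means among the compounds named here.

In a functional assay on HL-60 cells (Homo sapiens), read by MTT assay, with a stated time of 72 h (on this read-out lower numbers stand for stronger inhibition of growth and higher numbers for weaker inhibition of growth), compound 1 `O=c1cc(O)c2cccc(C(F)(F)F)c2[nH]1` gives only a limit of the assay, > 10000000 nM. Compound 2 `O=c1cc(O)c2cccc(F)c2[nH]1` likewise gives only a limit in this assay, > 10000000 nM. Within the data shown here, compound 3 `O=c1cc(O)c2ccc(C(F)(F)F)cc2[nH]1` gives 6200000 nM in this assay, the single number among the three measured compounds. The difference between the core of compound 1 and the core of compound 3 is not broken down here. The change from compound 1 to compound 2 is fluoro in place of trifluoromethyl on an aromatic carbon, and its step, a step that the two limits leave unreadable from compound 1 to compound 2, cannot be read because of the limit of > 10000000 nM in this assay, at which 2 of the 3 values shown sit. Compound 4 `O=c1cc(O)c2ccc(F)cc2[nH]1` carries the same kind of change relative to compound 3, (fluoro in place of trifluoromethyl on an aromatic carbon), but at a different place: meta to a fused ring and para to a fused ring rather than ortho to a fused ring and meta to a fused ring. With the earlier step of this kind unreadable, the expectation for compound 4 rests mainly on compound 3 sitting at 6200000 nM in this assay. Compound 4 is therefore expected to give roughly 9000000 nM in this assay, an estimated step of a 1.5-fold higher number from compound 3 to compound 4 (0.16 log units; within the scatter), with a plausible span from 3000000 nM to 30000000 nM.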

Compound 4, concentration for 50% growth inhibition: > 10000000 nM
Compound 4 ended at the assay's limit (the forecaster's own chance of this, stated with the estimate: 55%); middle value at least 1.1-fold (0.04 log units) away from the limit.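

In this assay, fluoro in place of trifluoromethyl on the core of compound 3 gives an at least 1.6-fold higher number from compound 3 to compound 4 (0.20 log units; that floor lies within the scatter), a step known only as a floor, so it is not shown to exceed the scatter. Among these compounds, the same change on the core of compound 1 leaves a step that cannot be read, so there is no second size to set against this one, and whether the change carries over with the same size stays unknown: the limit of > 10000000 nM in this assay, at which 3 of the 4 values shown sit. What the two pairs do show is only that both fluoro compounds, compound 2 and compound 4, end at the limit of the assay rather than at a number.

The compounds shown carry only trifluoromethyl or fluoro on the shared core, which leaves open how an amine, a carboxylic acid or a longer alkyl chain at these places would read in this assay. Also open, from the compounds shown here alone, is whether either fluoro compound truly differs from its trifluoromethyl partner by more than the scatter.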